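Aryl swap at the amine-side benzyl in a sulfonamide series

This account rests on a few compounds, and the source may have more. Where it says the series, first, only, none or still open, it means among the compounds named here.

Compound 1, `O=S(=O)(NCCCNCc1cccc2ccccc12)c1cc(C(F)(F)F)cc(C(F)(F)F)c1`, gives 1400 nM in a functional assay on MCF7 cells (Homo sapiens) for inhibition, read by MTT assay, with a stated time of 72 h; a higher number here means a weaker inhibitor of growth, a lower number a stronger inhibitor of growth. Compound 2, `O=S(=O)(NCCCNCc1ccc(Cl)cc1)c1cc(C(F)(F)F)cc(C(F)(F)F)c1`, gives 2400 nM in this assay. Of the two numbers available, compound 1 holds the lower one, but the gap to compound 2 is a 1.7-fold higher number from compound 1 to compound 2 (0.23 log units; within the scatter), so the two cannot be placed in order.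

Compound 3, `O=S(=O)(NCCCNCc1ccc(C(F)(F)F)cc1)c1cc(C(F)(F)F)cc(C(F)(F)F)c1`, is not yet measured. It differs from compound 1 as follows: 4-(trifluoromethyl)phenyl in place of naphthalen-1-yl on a saturated chain carbon bound to an amine nitrogen. For the measured compounds named here, the only measured step that bears on this change is the one in which 4-chlorophenyl replaces naphthalen-1-yl at the same place, a 1.7-fold higher number from compound 1 to compound 2 (0.23 log units; within the scatter). That step stayed within the scatter, so nothing measured indicates that exchanging naphthalen-1-yl for 4-(trifluoromethyl)phenyl on a saturated chain carbon bound to an amine nitrogen should move the number beyond the scatter. Compound 3 and compound 2 differ in the group on the phenyl ring, and no measurement speaks to that difference.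

Compound 3 is therefore expected to show a step of a 1.4-fold higher number from compound 1 to compound 3 (0.15 log units; within the scatter) and an estimated value of 2000 nM in this assay, with a range from 900 nM to 4500 nM.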

Compound 3, concentration for 50% growth inhibition: 1400 nM
Estimate against measurement, compound 3: 1.4-fold (0.15 log units) above, within the range that was stated.
By their numbers in this assay, from the lowest: compounds 1, 3 and 2 (each within the scatter of the next).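

In this assay the exchange at this place gives no change at the digits printed from compound 1 to compound 3 (within the scatter), so the naphthalen-1-yl group, with two six-membered aromatic rings, and the 4-(trifluoromethyl)phenyl group, with one, cannot be told apart by this read-out. For the compounds shown here, the new pair also gives the first reading on the group carried by the phenyl ring: trifluoromethyl in place of chloro on an aromatic carbon gives a 1.7-fold lower number from compound 2 to compound 3 (0.23 log units; within the scatter), and so compounds 1, 2 and 3 all lie within the scatter of one another, with no step among them that separates any two. Nothing at hand explains why these three groups read alike.

Whether any group on a saturated chain carbon bound to an amine nitrogen can move the number beyond the scatter remains open, as all three compounds shown carry a lipid-free set of aryl groups of similar reading only in this one assay. A carboxylic acid or an amine on the phenyl ring, or a longer chain in the linker of the core of compound 1, would test whether the flat reading holds beyond these three compounds.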